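Swapping the Ring at the End of the Chain

A few compounds are considered here, and "the series" means these few. Any claim that something is new, unique, unknown or untested is made for them only; others in the source may bear on it.

Measured compounds:
compound 1 `CCO/C(O)=C1\C(COCCn2ccnc2C)=NC(C)=C(C(=O)OC)C1c1ccccc1Cl` — 2.51 nM
compound 2 `CCO/C(O)=C1\C(COCCN2CC(=O)N=C2N)=NC(C)=C(C(=O)OC)C1c1ccccc1Cl` — 20 nM

In a functional assay (aorta) with Rattus norvegicus as the target (on this read-out lower numbers stand for stronger inhibition and higher numbers for weaker inhibition), compound 1 gives 2.51 nM, while compound 2 gives 20 nM. For the measured compounds named here, compound 2 therefore has the higher of the two numbers, and its only neighbour is compound 1: the step of an 8.0-fold higher number from compound 1 to compound 2 (0.90 log units; beyond the scatter) replaced an aromatic five-membered ring with a non-aromatic one. Compound 3 `CCOC(=O)c1cn(CCOCC2=NC(C)=C(C(=O)OC)C(c3ccccc3Cl)/C2=C(\O)OCC)nn1` now takes the opposite direction, with a group of 10 heavy atoms (5 carbon, 3 nitrogen, 2 oxygen; one five-membered aromatic ring with 3 hetero atoms) in place of a group of 7 heavy atoms (3 carbon, 3 nitrogen, 1 oxygen; one five-membered non-aromatic ring with 2 hetero atoms), on a saturated chain carbon, two bonds along the chain from an oxygen on a saturated carbon. The change brings back an aromatic five-membered ring, which is the feature compound 1 carried when it gave its lower number. Going by the values given here, the one step that bears on this, an 8.0-fold higher number from compound 1 to compound 2 (0.90 log units; beyond the scatter), was modest but beyond the scatter, so a step of similar size is expected in this assay, this time downward: a 4.0-fold lower number from compound 2 to compound 3 (0.60 log units; beyond the scatter). Compound 3 is thus estimated at 5 nM, with a plausible range from 1.5 nM to 20 nM.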

Compound 3, half-maximal inhibitory concentration: 50.1 nM
Compound 3: middle estimate off by 10-fold (1.00 log units), on the low side, outside the stated range (above it).
By their numbers in this assay, from the lowest: compound 1; then compound 2; then compound 3.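

Having an aromatic five-membered ring at the end of the chain is not enough to bring the number back down in this assay, since the 4-(ethoxycarbonyl)-1H-1,2,3-triazol-1-yl group gives a 2.5-fold higher number from compound 2 to compound 3 (0.40 log units; beyond the scatter) even though the group it replaces is non-aromatic. Set against 2-methyl-1H-imidazol-1-yl, the same group gives a 20-fold higher number from compound 1 to compound 3 (1.30 log units; beyond the scatter) as its large step, so two aromatic five-membered rings at this position can give very different numbers, and aromatic versus non-aromatic does not sort these three compounds. Nothing measured here accounts for this difference.

The two aromatic groups differ in both the ring and what it carries, so the compounds shown leave open which of these matters. A 1H-1,2,3-triazol-1-yl ring bearing a methyl, or a 1H-imidazol-1-yl ring bearing an ethoxycarbonyl, would help to separate the two.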